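The source may report more compounds than this note shows. Statements on the series, on what has been measured and on what is new or still open speak of the compounds shown alone.

Measured so far in a functional assay with Rattus norvegicus as the target; a lower number here means that less compound is needed, a higher number that more compound is needed for the effect:
compound 1 `CC1(C)C=C(n2ccccc2=O)c2cc(S(N)(=O)=O)ccc2O1` gives 224 nM
compound 2 `COc1ccc(NS(=O)(=O)c2ccc3c(c2)C(n2ccccc2=O)=CC(C)(C)O3)cc1` gives 490 nM

Going by the values given here, compound 2 stands at the higher of the two numbers in this assay; its only neighbour is compound 1, reached by 4-methoxyphenyl in place of hydrogen on the sulfonamide nitrogen.

Compound 3 `CC1(C)C=C(n2ccccc2=O)c2cc(S(=O)(=O)NC(=O)Nc3ccccc3)ccc2O1` has not yet been measured. It differs from compound 2 by phenylcarbamoyl in place of 4-methoxyphenyl on a sulfonamide nitrogen. Among the compounds with values here, no measured step covers this exchange directly. Within the data shown here, the only step that touches the same nitrogen is the one from compound 1 to compound 2, a 2.2-fold higher number from compound 1 to compound 2 (0.34 log units; beyond the scatter), which shows that occupying that nitrogen with an aryl group moved the number modestly and upward. Replacing one substituent on that nitrogen with another is therefore expected to yield a step of no more than modest size, with no clear direction; a result within the scatter of compound 2 is the most likely outcome. In this assay compound 3 is expected to give 450 nM (range 150 nM to 1400 nM). The step from compound 2 to compound 3 is thus estimated at a 1.1-fold lower number from compound 2 to compound 3 (0.04 log units; within the scatter).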

Compound 3, half-maximal effective concentration: 10000 nM
Compound 3: middle estimate off by 22-fold (1.35 log units), on the low side; the measured number lies above the stated range.
By their numbers in this assay, from the lowest: compound 1; then compound 2; then compound 3.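

In this assay the sulfonamide nitrogen proves far more sensitive to its substituent than the earlier pair suggested: the aryl group alone gave only a 2.2-fold higher number from compound 1 to compound 2 (0.34 log units; beyond the scatter), whereas phenylcarbamoyl gives a 45-fold higher number from compound 1 to compound 3 (1.65 log units; beyond the scatter). Exchanging one substituent for the other is therefore not a neutral swap, and it gives a 20-fold higher number from compound 2 to compound 3 (1.31 log units; beyond the scatter). Both groups carry one six-membered aromatic ring of carbon only, so the ring count does not separate them; the entering group differs in its added nitrogen, its double bond outside aromatic rings and its hydrogen-bond donor, and no measurement is available to explain the size of this step.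

The compounds shown leave open whether the large rise follows the carbonyl-containing link or the phenyl group at its end, which a comparison with acetyl or cyclohexylcarbamoyl on the same nitrogen would separate. They also leave open whether a small group such as methyl on that nitrogen stays close to compound 1 at 224 nM.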